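The source may report more compounds than this note shows. Statements on the series, on what has been measured and on what is new or still open speak of the compounds shown alone.

Measured in a functional assay on HeLa cells (Homo sapiens) for antiproliferative activity, with a stated time of 24 h; on this read-out lower numbers stand for stronger inhibition and higher numbers for weaker inhibition:
compound 1 `Cc1ccccc1C(=O)Nc1sc2c(c1C(N)=O)CCN(C(=S)Nc1ccccc1Cl)C2`: 35300 nM
compound 3 `Cc1ccccc1NC(=S)N1CCc2c(sc(NC(=O)c3ccccc3C(F)(F)F)c2C(N)=O)C1`: 47000 nM
compound 2 `COc1ccccc1C(=O)Nc1sc2c(c1C(N)=O)CCN(C(=S)Nc1ccccc1Cl)C2`: compound 2 returns only a limit of the assay, > 50000 nM.

Compound 4 `COc1ccccc1NC(=S)N1CCc2c(sc(NC(=O)c3ccccc3C(F)(F)F)c2C(N)=O)C1` is not yet measured. From compound 1 to compound 2 the change is methoxy in place of methyl on an aromatic carbon, and the step is an at least 1.4-fold higher number from compound 1 to compound 2 (0.15 log units; that floor lies within the scatter), the second number being (the limit of > 50000 nM in this assay, at which 1 of the 3 values shown sits). Compound 3 differs from compound 1 in more than one place; the difference between the two cores is not broken down here. The change from compound 3 to compound 4 is methoxy in place of methyl on an aromatic carbon, the same change as from compound 1 to compound 2, at a place described in the same words. Compound 3 stands near compound 1, within the scatter. Given the step of an at least 1.4-fold higher number from compound 1 to compound 2 (0.15 log units; that floor lies within the scatter), compound 4 is expected to give a weaker number, a step of a 1.6-fold higher number from compound 3 to compound 4 (0.20 log units; within the scatter). The estimate for compound 4 in this assay is 75000 nM, likely reported only as a limit.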

Compound 4, half-maximal inhibitory concentration: > 50000 nM
Compound 4 was reported as a limit; the forecaster's own chance of this, stated with the estimate: 65%; the middle value lies beyond the limit too.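

In this assay, methoxy in place of methyl on an aromatic carbon gives an at least 1.0-fold higher number from compound 3 to compound 4 (0.02 log units; that floor lies within the scatter). Beside the earlier step, the change points the same way on both cores, but only as far as the floors set by the limits can be read: the same change on two cores in this assay, an at least 1.4-fold higher number (0.15 log units; that floor lies within the scatter) from compound 1 to compound 2 and an at least 1.0-fold higher number (0.02 log units; that floor lies within the scatter) from compound 3 to compound 4; the limit leaves it open whether they differ. Neither step has a measured second number, so carrying the change from one core to the other cannot be given a size, and no transfer of its magnitude is shown: the limit of > 50000 nM in this assay, at which 2 of the 4 values shown sit.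

The compounds shown leave open how far above the limit compound 2 and compound 4 lie. They also leave open what an ethoxy, an amine or a carboxylic acid would give at the same place on the aromatic ring.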